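This account rests on a few compounds, and the source may have more. Where it says the series, first, only, none or still open, it means among the compounds named here.

Three compounds have been measured in an assay on CHO cells for displacement of a labelled ligand from adenosine receptor A3 (Homo sapiens), read by scintillation counting, with a stated time of 120 min, tested at 10 uM; on this read-out lower numbers stand for less inhibition and higher numbers for more inhibition at the one concentration tested (going by the name of the read-out):
compound 1 `COc1ccc(N2CCN(Cc3csc(N)c3C(=O)c3ccc(Cl)cc3)CC2)cc1` gives 0%;
compound 2 `Nc1scc(CN2CCN(c3ccc(Cl)c(C(F)(F)F)c3)CC2)c1C(=O)c1ccc(Cl)cc1` gives 3%;
compound 3 `Nc1scc(CN2CCN(c3cccnc3)CC2)c1C(=O)c1ccc(Cl)cc1` gives 0%.

All three share one core and differ only in the group on an amine nitrogen in a ring. Compound 3 stands level with compound 1 at the digits shown, the two together the lowest of the three numbers, and both steps of no change at the digits printed from compound 1 to compound 3 (within the scatter) and a number 3 percentage points lower from compound 2 to compound 3 (within the scatter) lie within the scatter. Compound 4 `Nc1scc(CN2CCN(c3cccc(F)c3)CC2)c1C(=O)c1ccc(Cl)cc1` differs from compound 3 in one place: 3-fluorophenyl in place of pyridin-3-yl on an amine nitrogen in a ring. The steps at this position that bear on it, a number 3 percentage points higher from compound 1 to compound 2 (within the scatter), no change at the digits printed from compound 1 to compound 3 (within the scatter) and a number 3 percentage points lower from compound 2 to compound 3 (within the scatter), all stayed within the scatter, so nothing beyond the scatter is expected here. The expected step is a number 2 percentage points higher from compound 3 to compound 4 (within the scatter). Compound 4 is therefore estimated at 2%, with a range from -5% to 10%.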

Compound 4, a percentage reported as inhibition, at one concentration (the size of the read-out at that concentration, not a potency): 4%
The estimate for compound 4 lay 2 percentage points below the measured number; measured number inside the range.
By their numbers in this assay, from the lowest: compounds 1, 3, 2 and 4 (each within the scatter of the next).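

Replacing pyridin-3-yl with 3-fluorophenyl removes the ring hetero atom and adds fluorine, and in this assay this gives a number 4 percentage points higher from compound 3 to compound 4 (within the scatter). Against the other two groups, 3-fluorophenyl gives a number 1 percentage points higher from compound 2 to compound 4 (within the scatter) and a number 4 percentage points higher from compound 1 to compound 4 (within the scatter) and so all four aromatic groups at this position now sit within the scatter of one another. Nothing on hand offers an explanation for these closely grouped numbers.

From the compounds shown here alone, what a carboxylic acid or a longer alkyl chain on this ring nitrogen would do stays open. So does whether changes elsewhere on the shared core would matter more.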